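The source may hold more compounds than are shown below. What is called first, only, known or untested is meant among the compounds shown, and "the series" means these compounds.

Compound 3 `CC1CC1COc1cccc2ccc(N)nc12` carries a 2-methylcyclopropyl group on the saturated chain carbon bound to the oxygen on the aromatic ring of the shared core. In an assay on cells with melanin-concentrating hormone receptor 1 (Homo sapiens) as the target, read by radioligand binding (a higher number here means a weaker inhibitor, a lower number a stronger inhibitor), compound 3 gives 1640 nM, the higher of the two numbers reported for the series. Compound 2 `Nc1ccc2cccc(OCCC(F)(F)F)c2n1`, with a 2,2,2-trifluoroethyl group in the same place, gives 722 nM in this assay. Compound 1 `CC#CCCOc1cccc2ccc(N)nc12` reaches only a limit in this assay, > 2000 nM, so no number is known for it (the limit of > 2000 nM in this assay, at which 1 of the 3 values shown sits). Going from compound 2 to compound 3 gave a 2.3-fold higher number from compound 2 to compound 3 (0.36 log units; beyond the scatter). The step of an at least 1.2-fold lower number from compound 1 to compound 3 (0.08 log units; that floor lies within the scatter) has a floor that lies within the scatter and tells little about direction.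

Compound 4 `CCCCOc1cccc2ccc(N)nc12` is the unmeasured member; its difference from compound 3 is propyl in place of 2-methylcyclopropyl on a saturated chain carbon bound to an oxygen on an aromatic ring. Among the compounds with values here, none of the measured steps swaps a ring for a plain chain at this carbon. The nearest comparisons are compound 1, a chain-bearing analogue sitting at its limit, and the step of a 2.3-fold higher number from compound 2 to compound 3 (0.36 log units; beyond the scatter), which went toward higher numbers when the ring entered. Nothing here shows a plain chain doing better than the ring. The author therefore expects compound 4 to land at about 2500 nM, within 900 nM to 7000 nM. The expected step is a 1.5-fold higher number from compound 3 to compound 4 (0.18 log units; within the scatter), and a limit rather than a number is a real possibility.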

Compound 4, half-maximal inhibitory concentration: 789 nM
Estimate against measurement, compound 4: 3.2-fold (0.50 log units) above; the whole stated range lies above it.
By their numbers in this assay, from the lowest: compounds 2 and 4 (each within the scatter of the next); then compound 3. At a limit, above all of these: compound 1.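

The plain chain does not lose ground to the ring at this place, and the direction runs against what the ring-bearing compound suggested: a 2.1-fold lower number from compound 3 to compound 4 (0.32 log units; beyond the scatter) in this assay, so the 2-methylcyclopropyl group offers no gain over butyl on the saturated chain carbon bound to an oxygen on an aromatic ring. Ethyl and trifluoromethyl at the end of the chain cannot be told apart, with a 1.1-fold higher number from compound 2 to compound 4 (0.04 log units; within the scatter), so the fluorines are not needed to reach this level of binding. The last step starts from a limit and not a number, which makes an at least 2.5-fold lower number from compound 1 to compound 4 (0.40 log units; beyond the scatter) a floor, yet that floor lies beyond the scatter and places ethyl ahead of prop-1-yn-1-yl at this place: the limit of > 2000 nM in this assay, at which 1 of the 4 values shown sits.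

On these data alone, whether the difference between butyl and the ring-bearing group lies with the ring or with its methyl stays open, since the change removes both at once, and a plain cyclopropylmethyl group would separate them. As far as these compounds go, how a pentyl chain, or a hydroxyl or an amine at the end of the butyl chain, would read in this assay also remains open.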